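Pyrimidine carbonitrile series: aryl amine swap on the bromophenyl core

A few compounds are considered here, and "the series" means these few. Any claim that something is new, unique, unknown or untested is made for them only; others in the source may bear on it.

Measured compounds:
- compound 1, `COc1cc(-c2nc(SCc3cn(CC(=O)NC(=O)Nc4ccccn4)nn3)nc(Nc3ccc(C(C)C)cc3)c2C#N)cc(OC)c1OC`: in a functional assay on ECa-109 cells (Homo sapiens) for inhibition, read by MTT assay, with a stated time of 72 h (on this read-out higher numbers stand for weaker inhibition and lower numbers for stronger inhibition), compound 1 gives > 64000 nM, which is a limit of the assay and not a number.
- compound 2, `COc1cc(-c2nc(SCc3cn(CC(=O)NC(=O)Nc4ccccn4)nn3)nc(Nc3cccc(C(F)(F)F)c3)c2C#N)cc(OC)c1OC`: in this assay compound 2 gives > 64000 nM, again a limit of the assay.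
- compound 3, `N#Cc1c(Nc2cccc(C(F)(F)F)c2)nc(SCc2cn(CC(=O)NC(=O)Nc3ccccn3)nn2)nc1-c1ccc(Br)cc1`: in this assay compound 3 gives 2960 nM, the only number in the set.

Compound 2 and compound 1 differ in one place: 4-isopropylphenyl in place of 3-(trifluoromethyl)phenyl on a nitrogen on an aromatic ring. The step that the two limits leave unreadable from compound 2 to compound 1 cannot be read, because the limit of > 64000 nM in this assay, at which 2 of the 3 values shown sit, holds both compounds. Compound 2 and compound 3 differ in their cores: 4-bromophenyl in place of 3,4,5-trimethoxyphenyl on an aromatic carbon. For the measured compounds named here, that change gives an at least 21-fold lower number from compound 2 to compound 3 (1.33 log units; beyond the scatter), the one readable step in the set.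

Compound 4, `CC(C)c1ccc(Nc2nc(SCc3cn(CC(=O)NC(=O)Nc4ccccn4)nn3)nc(-c3ccc(Br)cc3)c2C#N)cc1`, is not yet measured. It differs from compound 3 in the same way as compound 1 differs from compound 2: 4-isopropylphenyl in place of 3-(trifluoromethyl)phenyl on a nitrogen on an aromatic ring. The place lines of the two changes read the same word for word, so this is the same change, now made on the core of compound 3 rather than on the core of compound 2.

The earlier occurrence gives no size, so there is nothing measured to carry over. The expectation for compound 4 therefore rests only on compound 3 at 2960 nM. Compound 1 and compound 2 give only limits of the assay. The step from compound 3 to compound 4 is expected to be a 1.5-fold higher number from compound 3 to compound 4 (0.18 log units; within the scatter), small and uncertain. For compound 4 the estimate in this assay is 4500 nM, with a range from 1000 nM to 30000 nM expected.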

Compound 4, half-maximal inhibitory concentration: > 64000 nM
Compound 4 ended at the assay's limit; the forecaster's own chance of this, stated with the estimate: 25%; at least 14-fold (1.15 log units) between middle value and limit.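

On the core of compound 3, 4-isopropylphenyl in place of 3-(trifluoromethyl)phenyl on a nitrogen on an aromatic ring gives an at least 21-fold higher number from compound 3 to compound 4 (1.33 log units; beyond the scatter) in this assay, a large step beyond the scatter, and it is the only size available for this change. In this assay compound 4 gives > 64000 nM, which is a limit of the assay and not a number, so the step has a lower bound and no exact size. The steps from compound 2 to compound 1 and from compound 1 to compound 4 cannot be read, so the change is sized on one core only and nothing shows whether that size carries over to the core of compound 2, because these compounds all sit at one limit: the limit of > 64000 nM in this assay, at which 3 of the 4 values shown sit.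

The compounds shown leave open how other groups on that nitrogen would read on the core of compound 3, such as plain phenyl or a phenyl ring carrying an amine or a carboxylic acid. Also open, on these data alone, is whether the result for compound 4 follows from the loss of the trifluoromethyl group, from the arrival of the isopropyl group, or from both.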